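The compounds below may be only part of what the source reports. "The series", "measured", "known", "first", "only" and "open" are said of these compounds alone.

Compounds measured in a functional assay on MGC-803 cells (Homo sapiens) for inhibition, read by MTT assay, with a stated time of 72 h; on this read-out lower numbers stand for stronger inhibition and higher numbers for weaker inhibition: compound 1 `Cc1ccc(Cn2cc(CSc3nc(Nc4ccccc4C)c(C#N)c(-c4ccccc4)n3)nn2)cc1` gives > 64000 nM; compound 2 `Cc1ccc(Nc2nc(SCc3cn(Cc4ccc(Cl)cc4)nn3)nc(-c3ccccc3)c2C#N)cc1` gives 19600 nM; compound 3 `Cc1ccc(Nc2nc(SCc3cn(Cc4ccc(F)cc4)nn3)nc(-c3ccccc3)c2C#N)cc1` gives > 64000 nM.

Compound 3 stands at a limit of this assay: its value of > 64000 nM is not a number but the point where measurement stops. Compound 1 also sits at that limit, with > 64000 nM. Compound 2, with 19600 nM, is the only one of the three that yields a number. Among the compounds with values here, the single measured step, an at least 3.2-fold higher number from compound 2 to compound 3 (0.51 log units; beyond the scatter), runs up into (the limit of > 64000 nM in this assay, at which 2 of the 3 values shown sit), so its true size is not known.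

Compound 4 `Cc1ccc(Cn2cc(CSc3nc(Nc4ccc(C)cc4)c(C#N)c(-c4ccccc4)n3)nn2)cc1` differs from compound 3 by methyl in place of fluoro on an aromatic carbon. Within the data shown here, no measured step involves methyl in place of fluoro, and no pair of measured compounds shows this swap, so there is no direct guide. Compound 3 already stands at the limit, and compound 1, which also carries a 4-methylbenzyl group, sits there too. Compound 4 is therefore expected to stay near the limit, with a number no higher from compound 3 to compound 4 (the limit leaves the size open) estimated as no change beyond the scatter. The estimate for compound 4 is 64000 nM, with a range from 20000 nM to 200000 nM.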

Compound 4, half-maximal inhibitory concentration: > 64000 nM
Compound 4: a limit, no number; the forecaster's own chance of this, stated with the estimate: 70%; the middle value lies on the limit itself.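

In this assay compound 4 gives > 64000 nM, which is a limit and not a number. Methyl in place of chloro on this aromatic carbon, para to a large group, gives an at least 3.2-fold higher number from compound 2 to compound 4 (0.51 log units; beyond the scatter), so methyl now joins fluoro, and among the compounds shown only the 4-chlorobenzyl group of compound 2 yields a number. The steps from compound 3 and from compound 1 to compound 4 cannot be read, as both ends of each are limits: the limit of > 64000 nM in this assay, at which 3 of the 4 values shown sit.

Going by these compounds, whether fluoro and methyl differ from each other at this position, and whether 2-methylphenyl and 4-methylphenyl differ on the nitrogen, stays open. Also open, on these data alone, is whether bromo or methoxy in place of chloro would give a number, and whether chloro would still give one with 2-methylphenyl on that nitrogen.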